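The source may report more compounds than this note shows. Statements on the series, on what has been measured and on what is new or still open speak of the compounds shown alone.

In an ADME assay on the whole organism (Mus musculus) for pharmacokinetics, read by LC-MS, with a stated time of 24 h, at a dose of 1 mg/kg by the intravenous route (on this read-out higher numbers stand for higher exposure at the dose given and lower numbers for lower exposure), compound 1 (`COc1ccc(-c2cnn(C)c2)c2nc(NC(=O)N3CCC(C)(O)CC3)[nH]c12`) gives 3430 nM and compound 2 (`COc1ccc(-c2cnn(C)c2)c2nc(NC(=O)N3CC[C@@]4(CCCOC4)C3)[nH]c12`) gives 3510 nM in the same kind of measurement. Compound 3 (`COc1ccc(C2CCOCC2)c2ncc(NC(=O)N3CCC(C)(O)CC3)nc12`) gives 2270 nM and so lies within the usual scatter of both. Compound 4 (`COCCn1cc(C(=O)Nc2cnc3c(C4CCOCC4)ccc(OC)c3n2)cn1`) differs from compound 3 on the carbonyl carbon, with 1-(2-methoxyethyl)-1H-pyrazol-4-yl in place of 4-hydroxy-4-methylpiperidin-1-yl (1-(2-methoxyethyl)-1H-pyrazol-4-yl in place of 4-hydroxy-4-methylpiperidin-1-yl on a carbonyl carbon). Going by the values given here, the only measured step of this kind also exchanges the group on a carbonyl carbon (a 1.0-fold higher number from compound 1 to compound 2 (0.01 log units; within the scatter)) and stays within the scatter. Among the compounds with values here, that step swaps one non-aromatic group for another, whereas the entering group here has a five-membered aromatic ring, and no measured compound carries it, so the guide is a loose one. Compound 1 and compound 3 share the leaving group on different cores, and their numbers also stay within the scatter. No step beyond the scatter is expected in this assay, and the estimated step is modest (a 1.1-fold lower number from compound 3 to compound 4 (0.05 log units; within the scatter)). For compound 4 the estimated value is 2000 nM with an expected range from 950 nM to 4200 nM in repeat measurements.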

Compound 4, maximal plasma concentration: 2970 nM
For compound 4 the middle estimate is 1.5-fold (0.17 log units) below the measured one, within the range that was stated.
By their numbers in this assay, from the lowest: compounds 3, 4, 1 and 2 (each within the scatter of the next).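

In this assay, the aromatic 1-(2-methoxyethyl)-1H-pyrazol-4-yl takes the place of the non-aromatic 4-hydroxy-4-methylpiperidin-1-yl on the carbonyl carbon with a result that stays within the scatter (a 1.3-fold higher number from compound 3 to compound 4 (0.12 log units; within the scatter)). The earlier step at this carbonyl carbon only exchanged one non-aromatic group for another, whereas this one changes the ring type and drops the hydrogen-bond donor of the leaving group, and the read-out still shows no clear shift. The data offered here give no reason for this outcome.

The compounds shown leave open whether the 2-methoxyethyl chain matters, since none has a plain methyl or an amine-bearing chain on this pyrazole at the carbonyl carbon. On these data alone, it also remains open whether the same exchange would read alike on the core of compound 1.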